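This account rests on a few compounds, and the source may have more. Where it says the series, first, only, none or still open, it means among the compounds named here.

Measured so far:
compound 1, `CC(C)[C@H](NC(=O)COc1cccc2ccccc12)C(=O)N[C@@H](CC(=O)O)C(=O)CSc1nccn1C`: > 200000 nM
compound 2, `CC(C)[C@H](NC(=O)COc1cccc2ccccc12)C(=O)N[C@@H](CC(=O)O)C(=O)CSc1nc(-c2ccccc2)cs1`: > 200000 nM
compound 3, `CC(C)[C@H](NC(=O)COc1cccc2ccccc12)C(=O)N[C@@H](CC(=O)O)C(=O)CSc1nnc(-c2ccccc2)o1`: 150000 nM

In a functional assay on Jurkat cells (Homo sapiens) for inhibition (on this read-out higher numbers stand for weaker inhibition and lower numbers for stronger inhibition), compound 1 gives only a limit of the assay, > 200000 nM, and no number. Compound 2 also gives only a limit, > 200000 nM. Compound 3 gives a number, 150000 nM. The step of an at least 1.3-fold lower number from compound 1 to compound 3 (0.12 log units; that floor lies within the scatter) and the step of an at least 1.3-fold lower number from compound 2 to compound 3 (0.12 log units; that floor lies within the scatter) have floors within the scatter, and the step that the two limits leave unreadable from compound 1 to compound 2 cannot be read at all. Two of the three values sit at the limit of > 200000 nM in this assay, at which 2 of the 3 values shown sit.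

Compound 4, `CC(C)[C@H](NC(=O)COc1cccc2ccccc12)C(=O)N[C@@H](CC(=O)O)C(=O)COc1ccnc(C(F)(F)F)n1`, is not yet measured. It differs from compound 1 by (2-(trifluoromethyl)pyrimidin-4-yl)oxy in place of (1-methyl-1H-imidazol-2-yl)sulfanyl on a saturated chain carbon bound to a carbonyl carbon. The two measured steps that leave compound 1 exchanged only the ring hanging on the sulfur and kept that sulfur, whereas the change to compound 4 also replaces the sulfur by oxygen, so none of them covers it closely. Those steps were small or unreadable, and every value sits at or near the limit, so no step beyond the scatter is expected in this assay.

Compound 4 is therefore expected to give about 150000 nM, within 30000 nM to 400000 nM. That expectation corresponds to an estimated step of an at least 1.3-fold lower number from compound 1 to compound 4 (0.12 log units; that floor lies within the scatter).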

Compound 4, half-maximal inhibitory concentration: 37000 nM
Beside the measured number, compound 4's estimate is 4.1-fold (0.61 log units) above it; the range from low to high includes it.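

In this assay, changing the group on the saturated chain carbon bound to a carbonyl carbon now gives steps beyond the scatter, which the exchanges of the ring on the sulfur did not clearly show: an at least 5.4-fold lower number from compound 1 to compound 4 (0.73 log units; beyond the scatter), an at least 5.4-fold lower number from compound 2 to compound 4 (0.73 log units; beyond the scatter) and a 4.1-fold lower number from compound 3 to compound 4 (0.61 log units; beyond the scatter). Among the compounds shown, the (2-(trifluoromethyl)pyrimidin-4-yl)oxy group is thus the first change with a clear effect on this read-out. Two of these three steps give only a floor for their size: the limit of > 200000 nM in this assay, at which 2 of the 4 values shown sit.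

Compound 4 differs from the others in both its ring and the atom linking that ring, with oxygen in place of sulfur, and the compounds shown do not separate these two changes. As far as these compounds go, whether a phenoxy group or an amine at this place would lower the number further also remains open.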